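Methyl on the Piperidine Ring: Little Change Expected

This account rests on a few compounds, and the source may have more. Where it says the series, first, only, none or still open, it means among the compounds named here.

Measured compounds:
compound 1, `COc1cc2c(Oc3ccc(NC(=O)c4cn(-c5ccccc5C)nn4)cc3F)ccnc2cc1OCCCN1CCCCC1`, 1340 nM
compound 2, `COc1cc2c(Oc3ccc(NC(=O)c4cn(-c5ccc(Br)cc5)nn4)cc3F)ccnc2cc1OCCCN1CCCCC1`, 260 nM
compound 3, `COc1cc2c(Oc3ccc(NC(=O)c4cn(-c5ccc(F)c(F)c5)nn4)cc3F)ccnc2cc1OCCCN1CCCCC1`, 210 nM

All three compounds share one core and were tested in a functional assay on HT-29 cells (Homo sapiens) for cytotoxicity, read by MTT assay, with a stated time of 72 h; a higher number here means a weaker inhibitor, a lower number a stronger inhibitor. Compound 1 has the highest number of the three and is thus the weakest of them: the step of a 5.2-fold lower number from compound 1 to compound 2 (0.71 log units; beyond the scatter) and the step of a 6.4-fold lower number from compound 1 to compound 3 (0.80 log units; beyond the scatter) both go beyond the scatter, whereas the step of a 1.2-fold lower number from compound 2 to compound 3 (0.09 log units; within the scatter) stays within it. Each of those measured steps exchanges the aromatic group on the triazole nitrogen, and nothing else.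

Compound 4, `COc1cc2c(Oc3ccc(NC(=O)c4cn(-c5ccccc5C)nn4)cc3F)ccnc2cc1OCCCN1CCC(C)CC1`, keeps the 2-methylphenyl group of compound 1 and differs from it only by methyl in place of hydrogen on a saturated ring carbon. Among the measured compounds shown here, none of the measured steps involve that saturated ring, so no measured precedent exists for this change. Without such a precedent, the expectation is no step beyond the scatter, so the estimated step is no change at the digits printed from compound 1 to compound 4 (within the scatter). Compound 4 is therefore expected to give about 1340 nM in this assay, in an estimated range from 600 nM to 3000 nM.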

Compound 4, half-maximal inhibitory concentration: 2380 nM
Estimate against measurement, compound 4: 1.8-fold (0.25 log units) below, within the range that was stated.
By their numbers in this assay, from the lowest: compounds 3 and 2 (each within the scatter of the next); then compounds 1 and 4 (each within the scatter of the next).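

Placing a methyl on the piperidine ring gives the first reading from this part of the molecule: a 1.8-fold higher number from compound 1 to compound 4 (0.25 log units; within the scatter) in this assay, so 4-methylpiperidin-1-yl and piperidin-1-yl cannot be told apart here. The earlier steps shown here all exchanged the aromatic group on the triazole nitrogen and went beyond the scatter, as in a 6.4-fold lower number from compound 1 to compound 3 (0.80 log units; beyond the scatter), whereas this change on a saturated ring carbon, three ring bonds from the ring nitrogen, does not. Nothing measured here bears on the reason for this result.

The compounds shown pair this methyl only with the 2-methylphenyl group, so its effect alongside the 4-bromophenyl of compound 2 or the 3,4-difluorophenyl of compound 3 stays open. Also open, on these data alone, is how the same ring carbon would respond to a hydroxyl group, an amine or a longer chain.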